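This account rests on a few compounds, and the source may have more. Where it says the series, first, only, none or still open, it means among the compounds named here.

Measured so far in a functional assay on G-361 cells (Homo sapiens) for cytotoxicity, read by MTT assay, with a stated time of 3 days; a higher number here means a weaker inhibitor, a lower number a stronger inhibitor:
- compound 1 `N#Cc1c(O)nc(SCc2nc3ccccc3[nH]2)nc1-c1ccccc1` gives 3.43 nM
- compound 2 `N#Cc1c(Nc2ccccc2)nc(SCc2nc3ccccc3[nH]2)nc1-c1ccccc1` gives 2.4 nM

Compound 2 has the lower of these two numbers, but the gap is a 1.4-fold lower number from compound 1 to compound 2 (0.16 log units; within the scatter), so the pair cannot truly be ranked. The next compound, compound 3 `CCNc1nc(SCc2nc3ccccc3[nH]2)nc(-c2ccccc2)c1C#N`, keeps the rest of compound 2 and changes one group: ethyl in place of phenyl on a nitrogen on an aromatic ring. In words, this is ethyl in place of phenyl on a nitrogen on an aromatic ring, or anilino to ethylamino. Among the compounds with values here, only one measured step touches this part of the molecule, anilino in place of hydroxy on an aromatic carbon, and that step from compound 1 to compound 2 stayed within the scatter. Within the data shown here, no measured compound carries ethylamino, so this evidence is thin. No step beyond the scatter is therefore expected in this assay, and the estimate means a 1.3-fold higher number from compound 2 to compound 3 (0.10 log units; within the scatter). The estimated value for compound 3 is 3 nM, within an expected range from 1 nM to 9 nM.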

Compound 3, half-maximal inhibitory concentration: 4.38 nM
Compound 3: middle estimate off by 1.5-fold (0.16 log units), on the low side, within the range that was stated.
By their numbers in this assay, from the lowest: compounds 2, 1 and 3 (each within the scatter of the next).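

In this assay, ethyl in place of phenyl on the nitrogen gives only a small step (a 1.8-fold higher number from compound 2 to compound 3 (0.26 log units; within the scatter)), and ethylamino in place of hydroxy on the aromatic carbon gives another (a 1.3-fold higher number from compound 1 to compound 3 (0.11 log units; within the scatter)). Hydroxy, anilino and ethylamino at this place therefore cannot be told apart in this test, although ethyl has 2 heavy atoms and no ring where phenyl has 6 heavy atoms and a ring. Nothing among the data shown accounts for this lack of separation.

From the compounds shown here alone, whether a longer chain on the nitrogen, or a carboxylic acid on the aromatic carbon, would stand clearly apart from these three remains open. Going by these compounds, the nitrile and the rest of the core are the same in all three compounds, so their part in the cytotoxicity also stays unknown.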